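The compounds below may be only part of what the source reports. "The series", "measured", "known", "first", "only" and "open" are said of these compounds alone.

Working notes on the series. For the measured compounds named here, compound 1 `COc1cc(-c2nnc3n2NC(c2ccco2)C(C(=O)c2ccc(F)cc2)S3)cc(OC)c1OC` is the one member with a readable number: in a functional assay on A549 cells (Homo sapiens) for cytotoxicity, read by MTT assay, with a stated time of 48 h (a higher number here means a weaker inhibitor, a lower number a stronger inhibitor), compound 1 gives 53700 nM. Compound 2 `COc1cc(C(=O)C2Sc3nnc(-c4cc(OC)c(OC)c(OC)c4)n3NC2c2cccs2)cc(OC)c1OC` gives in this assay only the limit > 100000 nM. Compound 3 `COc1ccc(C(=O)C2Sc3nnc(-c4cc(OC)c(OC)c(OC)c4)n3NC2c2cccs2)cc1` gives in this assay only the limit > 100000 nM. Going by the values given here, the single step between measured compounds that differ in one place, a step that the two limits leave unreadable from compound 2 to compound 3, cannot be read from the two limits, so its size stays open. Compound 1 therefore stands alone as the only number shown, the other two resting at the limit of > 100000 nM in this assay, at which 2 of the 3 values shown sit.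

Compound 4 `COc1cc(-c2nnc3n2NC(c2ccco2)C(C(=O)c2ccc(C(F)(F)F)cc2)S3)cc(OC)c1OC` has not been measured. It differs from compound 1 by trifluoromethyl in place of fluoro on an aromatic carbon. Among the compounds with values here, no measured step exchanges these two groups, and the only step available is the unreadable one just described, so nothing in the data fixes the size or direction of this change. The set as a whole sits at weak inhibition, and the working assumption is that compound 4 stays in that region, without a step beyond the scatter in either direction.

The estimate for compound 4 in this assay is 60000 nM, with an expected range from 20000 nM to 150000 nM. The expected step of a 1.1-fold higher number from compound 1 to compound 4 (0.05 log units; within the scatter) is thus taken as no change beyond the scatter, with a fair chance that only a limit is returned.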

Compound 4, half-maximal inhibitory concentration: 37200 nM
For compound 4 the middle estimate is 1.6-fold (0.21 log units) above the measured one; low and high end bracket the measured number.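

In this assay, for the compounds shown here, the exchange at the aromatic carbon para to a large group gives a 1.4-fold lower number from compound 1 to compound 4 (0.16 log units; within the scatter), the first readable step. The position on the carbonyl-bearing ring therefore takes trifluoromethyl, with 4 heavy atoms, in place of fluoro, with 1, without a change beyond the scatter, so going from 4-fluorophenyl to 4-(trifluoromethyl)phenyl neither gains nor loses anything that this pair can show. Compound 4 also returns a number rather than a limit, as compound 1 does, which makes this pair readable, whereas the step from compound 2 to compound 3 cannot be read.

Going by these compounds, what an amine, a carboxylic acid or a longer chain at this same position would do stays open, and this single pair cannot say whether the same exchange would read the same way with the other substituents on the shared core. Readable comparisons in the series remain few, and any wider pattern stays unsupported: the limit of > 100000 nM in this assay, at which 2 of the 4 values shown sit.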